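The compounds below may be only part of what the source reports. "The series", "measured", "known", "first", "only" and "open" are said of these compounds alone.

Measured so far:
- Compound 1 `O=C(Nc1ccc(-c2cscn2)cc1)C1CCCN(Cc2ccc(F)c(F)c2)C1`: 1240 nM
- Compound 2 `O=C(Nc1ccc(-c2cscn2)cc1)[C@H]1CCCN(Cc2ccc(F)c(F)c2)C1`: 270 nM

In a functional assay on A-375 cells (Homo sapiens) for activation, with a stated time of 3 days (a higher number here means that more compound is needed for the effect, a lower number that less compound is needed), compound 1 gives 1240 nM, the higher of the two numbers, so it needs more compound for the effect. The next compound to test is compound 3 `O=C(Nc1ccc(-c2cscn2)cc1)C1CCCN(Cc2cc(F)cc(F)c2)C1`. It has the same atoms, joined differently: 3,5-difluorophenyl in place of 3,4-difluorophenyl on a saturated chain carbon bound to an amine nitrogen in a ring. In short, 3,5-difluorophenyl stands in place of 3,4-difluorophenyl on a saturated chain carbon bound to an amine nitrogen in a ring.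

Among the measured compounds shown here, the only measured step, a 4.6-fold lower number from compound 1 to compound 2 (0.66 log units; beyond the scatter), goes with the fact that one of compounds 1 and 2 is drawn with a defined configuration and the other without, at the place where they differ. It concerns configuration, not the fluorine pattern, so it gives no direction for this change and serves only as a rough guide to how far this assay can move. No step beyond the scatter is therefore expected, though with a wide margin. The estimated change is a 1.0-fold lower number from compound 1 to compound 3 (0.01 log units; within the scatter). For compound 3 the expected value is 1200 nM, with an estimated range from 400 nM to 3600 nM.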

Compound 3, half-maximal effective concentration: 1500 nM
Compound 3: middle estimate off by 1.3-fold (0.10 log units), on the low side; the measured number falls inside the stated range.
By their numbers in this assay, from the lowest: compound 2; then compounds 1 and 3 (each within the scatter of the next).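

In this assay, putting 3,5-difluorophenyl in place of 3,4-difluorophenyl gives a 1.2-fold higher number from compound 1 to compound 3 (0.08 log units; within the scatter) and so stays inside the normal spread of repeated measurements. Among the compounds shown here, this is the first measured change in the group on a saturated chain carbon bound to an amine nitrogen in a ring, and in this single pair, rearranging the two fluorines on the phenyl ring does not produce a readable difference. Nothing given here speaks to why the number holds in this pair.

Going by these compounds, compounds 1 and 3 are both drawn without a defined configuration, so it remains open whether the same swap would hold in the S form of compound 2. Also open, on these data alone, is how this assay responds when the fluorines give way to other groups on the phenyl ring, such as chlorine or methoxy, or when the ring carries no substituent at all.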